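Notes on the chain-end change from compound 1 to compound 3

The source may hold more compounds than are shown below. What is called first, only, known or untested is meant among the compounds shown, and "the series" means these compounds.

compound 1, `COC(=O)CCCCCCCCn1nc(-c2ccccc2)c(-c2ccccc2)c1-c1ccccc1`: 4300 nM
compound 2, `O=C(O)CCCCCCCCn1cc(-c2ccccc2)cn1`: > 105000 nM

In a functional assay for inhibition, with Homo sapiens as the target (a lower number here means a stronger inhibitor, a higher number a weaker inhibitor), compound 1 gives 4300 nM, the only number shown in the set. For compound 2 the result is a limit of the assay rather than a number, > 105000 nM, as recorded under (the limit of > 105000 nM in this assay, at which 1 of the 2 values shown sits). Compound 3, `O=C(O)CS(=O)(=O)CCCCCCn1nc(-c2ccccc2)c(-c2ccccc2)c1-c1ccccc1`, differs from compound 1 by (carboxymethyl)sulfonyl in place of 2-(methoxycarbonyl)ethyl on a saturated chain carbon, six bonds along the chain from an aromatic nitrogen. No measured step between compounds is shown, so the size of this change is uncertain; a step within the usual scatter, or a modest loss, is expected. Compound 3 is estimated at 6000 nM, between 1500 nM and 25000 nM, an expected step of a 1.4-fold higher number from compound 1 to compound 3 (0.14 log units; within the scatter).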

Compound 3, half-maximal inhibitory concentration: 22000 nM
For compound 3 the middle estimate is 3.7-fold (0.56 log units) below the measured one, within the range that was stated.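

In this assay, placing (carboxymethyl)sulfonyl in place of 2-(methoxycarbonyl)ethyl on a saturated chain carbon, six bonds along the chain from an aromatic nitrogen, gives a 5.1-fold higher number from compound 1 to compound 3 (0.71 log units; beyond the scatter). The position therefore responds to this change, though the loss is modest and a measurable number remains. Nothing shown bears on the cause of this step.

Whether the sulfonyl or the acid end accounts for the step stays open, since both enter together. The core of compound 1 with a carboxylic acid on an all-carbon chain would part the two, and a primary amide at the chain end remains unplaced.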